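This account rests on a few compounds, and the source may have more. Where it says the series, first, only, none or still open, it means among the compounds named here.

Measured in a functional assay on HeLa cells (Homo sapiens) for cytotoxicity, read by MTT assay, with a stated time of 24 h; on this read-out higher numbers stand for weaker inhibition and lower numbers for stronger inhibition:
- compound 1 `C=CC1=C(C(=O)NCCC)C(c2ccc(F)cc2)OC1`, a limit of the assay only: > 100000 nM
- compound 2 `C=CC1=C(C(=O)NCc2ccc(C)cc2)C(c2ccc(F)cc2)OC1`, a limit of the assay only: > 100000 nM

For the measured compounds named here, compound 2 stands at the limit of > 100000 nM in this assay, at which 2 of the 2 values shown sit, so it cannot be placed on a scale against compound 1, and the only measured step, a step that the two limits leave unreadable from compound 1 to compound 2, gives no size. Compound 3 `C=CC1=C(C(=O)NCc2ccc(Cl)cc2)C(c2ccc(F)cc2)OC1` differs from compound 2 by chloro in place of methyl on an aromatic carbon. Going by the values given here, no measured step bears on this change, since the single recorded step is itself unreadable. The expectation for compound 3 can rest only on compound 2 showing no measurable inhibition at the limit. A step that the limit leaves unreadable from compound 2 to compound 3 in this assay is expected for compound 3, that is, none beyond the scatter, with a limit rather than a number the most likely report. The estimate for compound 3 is 150000 nM, with a range from 50000 nM to 500000 nM.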

Compound 3, half-maximal inhibitory concentration: > 100000 nM
Compound 3 ended at the assay's limit (the forecaster's own chance of this, stated with the estimate: 85%); the middle value is on the limit's open side.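

For the compounds shown here, no step among compound 1, compound 2 and compound 3 can be read in this assay because each value is only a limit: the limit of > 100000 nM in this assay, at which 3 of the 3 values shown sit.

The compounds shown leave open whether any change to the amide substituent brings a value inside the measurable range.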